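Working notes: compound 4 against compounds 1 to 3

This account rests on a few compounds, and the source may have more. Where it says the series, first, only, none or still open, it means among the compounds named here.

Measured compounds:
- compound 1, `C[C@@H](CNc1ccc(OC(F)(F)F)cc1)NC(=O)[C@H](CC1CCCCC1)NC(=O)C1CCOC1`; in an assay on isolated protein for inhibition of cathepsin S (Homo sapiens) (on this read-out lower numbers stand for stronger inhibition and higher numbers for weaker inhibition), compound 1 gives 21 nM
- compound 2, `C[C@@H](CNc1ccc(OC(F)(F)F)cc1)NC(=O)[C@H](CC1CCCCC1)NC(=O)O[C@@H]1CCOC1`; compound 2 gives 42 nM
- compound 3, `C[C@@H](CNc1ccc(OC(F)(F)F)cc1)NC(=O)[C@H](CC1CCCCC1)NC(=O)N1CCOCC1`; compound 3 gives 11 nM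

Among the measured compounds shown here, compound 3 has the lowest number of the three, but only the step of a 3.8-fold lower number from compound 2 to compound 3 (0.58 log units; beyond the scatter) is beyond the scatter; the step of a 1.9-fold lower number from compound 1 to compound 3 (0.28 log units; within the scatter) is within it, so compound 3 and compound 1 cannot be ordered. Compound 4, `C[C@@H](CNc1ccc(OC(F)(F)F)cc1)NC(=O)[C@H](CC1CCCC1)NC(=O)N1CCOCC1`, differs from compound 3 by cyclopentyl in place of cyclohexyl on a saturated chain carbon, two bonds along the chain from an amide-type nitrogen and a carbonyl carbon. All three measured steps (a 2.0-fold higher number from compound 1 to compound 2 (0.30 log units; within the scatter), a 1.9-fold lower number from compound 1 to compound 3 (0.28 log units; within the scatter), a 3.8-fold lower number from compound 2 to compound 3 (0.58 log units; beyond the scatter)) change the group on the carbonyl carbon, not this chain carbon, so none bears directly on the step to compound 4. For the measured compounds named here, with no precedent, the expectation for this assay is no step beyond the scatter, a 1.6-fold higher number from compound 3 to compound 4 (0.21 log units; within the scatter). Compound 4 is therefore estimated at 18 nM, with a range of 6 nM to 55 nM.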

Compound 4, inhibition constant: 49 nM
Beside the measured number, compound 4's estimate is 2.7-fold (0.43 log units) below it; the range from low to high includes it.
By their numbers in this assay, from the lowest: compounds 3, 1, 2 and 4 (each within the scatter of the next, the first and the last beyond it).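

In this assay, the saturated chain carbon responds on its own: with the group on the carbonyl carbon held as morpholin-4-yl, cyclopentyl in place of cyclohexyl gives a 4.5-fold higher number from compound 3 to compound 4 (0.65 log units; beyond the scatter), a step beyond the scatter. So the ring on this carbon matters to the read-out, and a change of one ring carbon is enough to show it. Nothing measured here gives a reason for this step.

Open, on these data alone, is whether cycloheptyl or an open isobutyl chain on this carbon would track cyclohexyl or cyclopentyl. Also open, as far as these compounds go, is whether the same ring change gives a similar step with the oxolan-3-yl group of compound 1.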